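Replacing a Hydroxy-Methylphenyl Arm with a Dichlorophenyl Arm

A few compounds are considered here, and "the series" means these few. Any claim that something is new, unique, unknown or untested is made for them only; others in the source may bear on it.

Compound 1 `O=C1Nc2ccc(Br)cc2/C1=N/NC(=S)N/N=C/c1c(Cl)cccc1Cl` gives 3530 nM in a functional assay on HeLa cells (Homo sapiens) for inhibition, read by MTT assay; a higher number here means a weaker inhibitor, a lower number a stronger inhibitor.
Compound 2 `COc1ccc(/C=N/NC(=S)N/N=C2\C(=O)Nc3ccc(C)cc32)cc1O` gives 2730 nM in this assay.
Compound 3 `Cc1ccc(O)c(/C=N/NC(=S)N/N=C2\C(=O)Nc3ccc(C)cc32)c1` gives > 50000 nM in this assay, which is a limit of the assay and not a number.

Compound 3 thus stands at the limit of > 50000 nM in this assay, at which 1 of the 3 values shown sits, with no number of its own. Going by the values given here, the one measured step reaching it, an at least 18-fold higher number from compound 2 to compound 3 (1.26 log units; beyond the scatter), is large. Compound 4 `Cc1ccc2c(c1)/C(=N/NC(=S)N/N=C/c1c(Cl)cccc1Cl)C(=O)N2` arises from compound 3 through (2,6-dichlorophenyl in place of 2-hydroxy-5-methylphenyl on a carbon with a double bond to nitrogen). Among the compounds with values here, no measured step covers this exact exchange, but compound 1 carries the same 2,6-dichlorophenyl on a different core and gives 3530 nM, while the step of an at least 18-fold higher number from compound 2 to compound 3 (1.26 log units; beyond the scatter) shows that the aryl arm alone can shift the number greatly. A large fall in the number is therefore expected, an at least 12-fold lower number from compound 3 to compound 4 (1.09 log units; beyond the scatter). Compound 4 is estimated at 4000 nM, between 1500 nM and 15000 nM.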

Compound 4, half-maximal inhibitory concentration: 1790 nM
The estimate for compound 4 lay 2.2-fold (0.35 log units) above the measured number; the range from low to high includes it.
By their numbers in this assay, from the lowest: compounds 4, 2 and 1 (each within the scatter of the next). At a limit, above all of these: compound 3.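

The 2,6-dichlorophenyl arm brings the core of compound 3 clear of its limit (an at least 27-fold lower number from compound 3 to compound 4 (1.44 log units; beyond the scatter)). This arm and the 3-hydroxy-4-methoxyphenyl arm cannot be told apart on the shared core (a 1.5-fold lower number from compound 2 to compound 4 (0.18 log units; within the scatter)), and methyl in place of bromo on an aromatic carbon also stays within the scatter (a 2.0-fold lower number from compound 1 to compound 4 (0.29 log units; within the scatter)). Compound 3 stands at a limit of the assay and not a number, so the size of its step is only a bound: the limit of > 50000 nM in this assay, at which 1 of the 4 values shown sits.

The compounds shown leave open whether an amine or a carboxylic acid on the aryl arm would keep the number in this range.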